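The compounds below may be only part of what the source reports. "The series", "measured", "known", "first", "only" and "open" are said of these compounds alone.

Series notes, compounds measured so far:

compound 1, `C=Cc1cn2ncc(-c3ccnc(OC)c3)c2nc1NC`, in an assay on isolated protein for inhibition of activin receptor type-2A (Homo sapiens), read by 33P incorporation, with a stated time of 20 min, in the presence of a further agent that is not named here; on this read-out lower numbers stand for stronger inhibition and higher numbers for weaker inhibition: 190 nM
compound 2, `COc1cc(-c2cnn3cc(OC)c(C4CCCC4)nc23)ccn1`, in this assay: 2900 nM

Within the data shown here, compound 2 holds the highest number of the two measured so far; compound 1 sits well below it, and the gap between the two lies beyond the usual scatter. Among the measured compounds shown here, no single-change step between measured compounds is available, so the effect of the next change can only be guessed.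

Compound 3, `COc1cc(-c2cnn3cc(OC)c(-c4cnn(C)c4)nc23)ccn1`, is not yet measured. It differs from compound 2 in one place: 1-methyl-1H-pyrazol-4-yl in place of cyclopentyl on an aromatic carbon. The cyclopentyl leaves and a 1-methyl-1H-pyrazol-4-yl enters on the aromatic carbon next to the ring nitrogen, ortho to the methoxy group.

For the measured compounds named here, with no measured step to lean on, the expectation for compound 3 is a modest move toward a lower number in this assay, around the edge of the scatter, expressed as a 2.9-fold lower number from compound 2 to compound 3 (0.46 log units; beyond the scatter). Compound 3 is therefore estimated at 1000 nM in this assay, with a range from 250 nM to 4500 nM.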

Compound 3, half-maximal inhibitory concentration: 530 nM
Estimate against measurement, compound 3: 1.9-fold (0.28 log units) above; low and high end bracket the measured number.
By their numbers in this assay, from the lowest: compound 1; then compound 3; then compound 2.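

Among these compounds, on the aromatic carbon next to the ring nitrogen, ortho to the methoxy group, the read-out responds to the group placed there: in this assay the change from cyclopentyl to 1-methyl-1H-pyrazol-4-yl gives a 5.5-fold lower number from compound 2 to compound 3 (0.74 log units; beyond the scatter), the first single-change step and one beyond the usual scatter. Here, a five-membered aromatic ring with 2 hetero atoms gives a lower number than a five-membered non-aromatic ring of carbon only. The data do not separate the contributions of the ring nitrogens, the aromatic ring and the methyl group, and no supporting evidence accounts for the step.

Still open, from the compounds shown here alone, is how an amine such as morpholine, or the unsubstituted pyrazole, would behave at this carbon. Compound 1 differs from compound 3 in more than one place, so the contribution of its groups cannot be read.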